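The compounds below may be only part of what the source reports. "The series", "measured", "known", "first", "only" and "open" are said of these compounds alone.

Compound 1 `Cc1cccc(COc2cccc(/C=C3\C(=O)NN(c4ccccc4[N+](=O)[O-])C3=O)c2)c1` gives 5370 nM in a functional assay on cells for agonist activity at Bile acid receptor (Homo sapiens), read by a luciferase reporter; on this read-out lower numbers stand for an effect already at smaller amounts and higher numbers for an effect only at larger amounts of compound. Compound 2 `Cc1cccc(COc2cccc(/C=C3\C(=O)NN(C(=O)c4ccc(F)cc4)C3=O)c2)c1` gives 1860 nM in this assay.

Compound 2 holds the lower of the two numbers, the step of a 2.9-fold lower number from compound 1 to compound 2 (0.46 log units; beyond the scatter) lying beyond the scatter. Compound 3 `Cc1cccc(COc2cccc(/C=C3\C(=O)NN(C(=O)c4ccncc4)C3=O)c2)c1` differs from compound 2 by pyridin-4-yl in place of 4-fluorophenyl on a carbonyl carbon. For the measured compounds named here, the one measured step, a 2.9-fold lower number from compound 1 to compound 2 (0.46 log units; beyond the scatter), reworked the same nitrogen-borne group but exchanged a different kind of group, so it bears only loosely on this smaller change; no measured step swaps one ring atom in this way. The step expected is a 1.3-fold higher number from compound 2 to compound 3 (0.13 log units; within the scatter), within the scatter. Compound 3 is estimated at 2500 nM in this assay, ranging from 800 nM to 8000 nM.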

Compound 3, half-maximal effective concentration: 2400 nM
Compound 3: the middle estimate sits 1.0-fold (0.02 log units) above what was measured, within the range that was stated.
By their numbers in this assay, from the lowest: compounds 2 and 3 (each within the scatter of the next); then compound 1.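

On a carbonyl carbon, pyridin-4-yl can replace 4-fluorophenyl with no change that stands out from the scatter in this assay, as a 1.3-fold higher number from compound 2 to compound 3 (0.11 log units; within the scatter) shows. A ring nitrogen can therefore take the place of the fluorine-bearing ring carbon without losing the advantage over the 2-nitrophenyl group, with a 2.2-fold lower number from compound 1 to compound 3 (0.35 log units; beyond the scatter) still beyond the scatter. No measured evidence here explains this result.

As far as these compounds go, whether an amine, a carboxylic acid or pyridin-3-yl on that carbonyl carbon would move the number beyond the scatter stays open.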